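Same Atoms, New Linkage: Estimating Compound 4

The source may report more compounds than this note shows. Statements on the series, on what has been measured and on what is new or still open speak of the compounds shown alone.

Compound 1 `Cc1cc(Cl)cc(-c2ccnc3cc(CN4C(=O)C5CC5C4=O)sc23)c1O[C@@H]1CCNC[C@@H]1C`: 1.1 nM
Compound 2 `Cc1cc(Cl)cc(-c2ccnc3cc(CN4C(=O)CCC4=O)sc23)c1O[C@@H]1CCNC[C@@H]1C`: 2.1 nM
Compound 3 `Cc1cc(Cl)cc(-c2ccnc3cc(CN4C(=O)C5C(C4=O)C5(C)C)sc23)c1OC1CCCNC1`: 2.4 nM

Of the compounds shown here, three have been measured in an assay on isolated protein for inhibition of ubiquitin carboxyl-terminal hydrolase 7 (Homo sapiens), read by fluorescence, with stated times of 30 min and 1 h; a higher number here means a weaker inhibitor, a lower number a stronger inhibitor. Compound 1 holds the lowest of the three numbers. Compound 2 sits nearest, and the step of a 1.9-fold higher number from compound 1 to compound 2 (0.28 log units; within the scatter) lies within the scatter, so the two cannot be ordered. Compound 3 lies further off, beyond the scatter from compound 1, while also carrying a different amine ring, so its gap cannot be tied to one change.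

Compound 4 `Cc1cc(Cl)cc(-c2ccnc3cc(CN4C(=O)C5CC5C4=O)sc23)c1C[C@@H]1CNC[C@@H](C)O1` is built from the same atoms as compound 1, joined differently: (6-methylmorpholin-2-yl)methyl in place of (3-methylpiperidin-4-yl)oxy on an aromatic carbon. Going by the values given here, no measured step touches this part of the molecule. The only step shown, a 1.9-fold higher number from compound 1 to compound 2 (0.28 log units; within the scatter), concerns the group on the saturated chain carbon bound to an aromatic carbon and leaves the amine ring untouched, so it offers no guide to the size or direction of the change from compound 1 to compound 4. All three measured compounds carry a saturated amine ring at this position and all give low numbers, but the rearrangement here is larger than any step seen.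

Compound 4 is therefore expected to give 4 nM, between 1 nM and 25 nM, a step of a 3.6-fold higher number from compound 1 to compound 4 (0.56 log units; beyond the scatter) that is estimated with little support from the measured data.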

Compound 4, half-maximal inhibitory concentration: 0.39 nM
Estimate against measurement, compound 4: 10-fold (1.01 log units) above; the measured number lies below the stated range.
By their numbers in this assay, from the lowest: compound 4; then compounds 1, 2 and 3 (each within the scatter of the next, the first and the last beyond it).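

In this assay, (6-methylmorpholin-2-yl)methyl in place of (3-methylpiperidin-4-yl)oxy gives a 2.8-fold lower number from compound 1 to compound 4 (0.45 log units; beyond the scatter), a modest change that takes the number lower. The earlier compounds shown here all hold a saturated amine ring on this aromatic carbon through an oxygen, whereas compound 4 shows that a (6-methylmorpholin-2-yl)methyl group is accepted at this place, ortho to a large group and to a methyl group, without any loss in this assay. The two groups match in heavy atoms, hydrogen-bond donors, hydrogen-bond acceptors and defined stereocentres, and no measurement here accounts for the shift.

The step changes the link and the ring together, so the compounds shown leave open how much of it belongs to each, a question that a (3-methylpiperidin-4-yl)methyl group or a morpholine ring joined through oxygen would address. They also leave open whether the same shift would appear with the plain five-membered imide of compound 2, or with a longer chain between the ring and the aromatic carbon.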